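Formyl to (morpholin-4-yl)carbonyl on the shared core

A few compounds are considered here, and "the series" means these few. Any claim that something is new, unique, unknown or untested is made for them only; others in the source may bear on it.

Of the compounds shown here, two have values so far. In a functional assay on U-937 cells (Homo sapiens) (on this read-out lower numbers stand for stronger inhibition and higher numbers for weaker inhibition), compound 1 `COc1cc(C(=O)NS(=O)(=O)c2ccccc2C)ccc1Cc1cn(C(F)F)c2ccc(NC(=O)OC3CCCC3)cc12` gives 0.4 nM, and compound 2 `COc1cc(C(=O)NS(=O)(=O)c2ccccc2C)ccc1Cc1cn(C=O)c2ccc(NC(=O)OC3CCCC3)cc12` gives 0.6 nM. These two values lie within the scatter of each other, so compound 2 stands level with compound 1 on the available numbers.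

Compound 3 `COc1cc(C(=O)NS(=O)(=O)c2ccccc2C)ccc1Cc1cn(C(=O)N2CCOCC2)c2ccc(NC(=O)OC3CCCC3)cc12` keeps the core of compound 2 and differs in one place: morpholin-4-yl in place of hydrogen on a carbonyl carbon. This puts morpholin-4-yl in place of hydrogen on a carbonyl carbon, turning formyl into (morpholin-4-yl)carbonyl.

Among the measured compounds shown here, the one measured step that bears on this is a 1.5-fold higher number from compound 1 to compound 2 (0.18 log units; within the scatter), formyl in place of difluoromethyl on an aromatic nitrogen. From that step alone, no change beyond the scatter is expected for compound 3 in this assay. For the measured compounds named here, neither compound 1 nor compound 2 carries a ring in this place, so the data offer no direct precedent and the range is kept wide. The estimated step is a 1.3-fold higher number from compound 2 to compound 3 (0.12 log units; within the scatter). For compound 3 the expected value is 0.8 nM, with an estimated range of 0.25 nM to 3 nM.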

Compound 3, half-maximal inhibitory concentration: 2 nM
Beside the measured number, compound 3's estimate is 2.5-fold (0.40 log units) below it, within the range that was stated.
By their numbers in this assay, from the lowest: compounds 1 and 2 (each within the scatter of the next); then compound 3.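

In this assay, the substituent on the aromatic nitrogen is shown for the first time to affect the read-out: the earlier exchange gave only a 1.5-fold higher number from compound 1 to compound 2 (0.18 log units; within the scatter), whereas morpholin-4-yl in place of hydrogen on the carbonyl carbon gives a 3.3-fold higher number from compound 2 to compound 3 (0.52 log units; beyond the scatter). Measured against the difluoromethyl group, the (morpholin-4-yl)carbonyl group gives a 5.0-fold higher number from compound 1 to compound 3 (0.70 log units; beyond the scatter), so this position accepts a carbonyl bearing a six-membered non-aromatic ring at a modest loss, and compound 3 still reads 2 nM. No measurement is available that accounts for this loss.

The compounds shown do not separate the contribution of the ring from that of the amide-type attachment through its nitrogen, a question that dimethylamino on the same carbonyl carbon would address. Nor do they show whether the ring oxygen matters, which piperidin-1-yl in place of morpholin-4-yl would test, or whether a simple methyl on the carbonyl carbon, giving acetyl, would stay level with compound 2.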